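This account rests on a few compounds, and the source may have more. Where it says the series, first, only, none or still open, it means among the compounds named here.

The series rests on one shared core, which compound 1 `O=c1nc(SCc2ccccc2)nc(SCc2ccccc2F)[nH]1` shows in full; in an assay for inhibition of Pro-cathepsin H (Homo sapiens), read by fluorescence, tested at 50 uM (on this read-out lower numbers stand for less inhibition and higher numbers for more inhibition at the one concentration tested (going by the name of the read-out)), compound 1 gives "not determined" (no result reported). Among the compounds with values here, compound 2 `CCSc1nc(SCc2ccccc2)nc(=O)[nH]1` carries the only number in the set: in this assay compound 2 gives -4.06%, a reading that amounts to no measurable inhibition at the concentration used. Compound 3 `O=c1nc(SCc2ccccc2)nc(SCC2CCC2)[nH]1` differs from compound 2 in one place, (cyclobutyl in place of methyl on a saturated chain carbon bound to a sulfur). Within the data shown here, no two measured compounds in this set differ in a single place, so the usual size of such a step in this assay cannot be read from the data at hand. Given that compound 2 gives -4.06%, the expectation for the step from compound 2 to compound 3 is a small one, a number 6.1 percentage points higher from compound 2 to compound 3 (within the scatter), not clearly beyond the scatter of repeated measurements. Compound 3 is therefore estimated to give 2% in this assay, with a range from -10% to 18%.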

Compound 3, a percentage reported as inhibition, at one concentration (the size of the read-out at that concentration, not a potency): 1.57%
For compound 3 the middle estimate is 0.4 percentage points above the measured one; the range from low to high includes it.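

In this assay, putting cyclobutyl in place of methyl on a saturated chain carbon bound to a sulfur gives a number 5.6 percentage points higher from compound 2 to compound 3 (within the scatter) and so does not separate the two compounds. Until now a single number stood for the series; this first step shows that adding a four-membered carbon ring at this place does not bring out measurable inhibition at the one concentration tested, since compound 3 gives 1.57% and thus stays close to zero, as compound 2 does. Nothing available on these compounds bears on why the reading stays there.

What the compounds shown leave open is whether any group at this place can raise the reading. An amine, a carboxylic acid or a longer chain on that sulfur might behave differently from methyl and cyclobutyl, and the present data cannot say.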